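A few compounds are considered here, and "the series" means these few. Any claim that something is new, unique, unknown or untested is made for them only; others in the source may bear on it.

For the measured compounds named here, the three compounds measured so far are alike in their core and differ in the parts attached to it. Compound 1 `O=C1[C@@H](NS(=O)(=O)c2ccc(-c3ccon3)s2)CCN1CCNc1ccncc1` was tested in an assay on isolated protein for inhibition of coagulation factor X (Oryctolagus cuniculus), tested at 1 uM (on this read-out higher numbers stand for more inhibition at the one concentration tested (going by the name of the read-out) and lower numbers for less inhibition), and gives 22%. Going by the values given here, compound 3 `O=C1[C@@H](NS(=O)(=O)c2cc3cccnc3s2)CCN1CCNc1ccncc1` gives 23% in this assay, a number within the usual scatter of the one found for compound 1, so the two cannot be told apart. Compound 2 `Cc1c(S(=O)(=O)N[C@H]2CCN(Cc3cc4c[nH]ccc-4n3)C2=O)sc2ccc(Cl)cc12` gives 37% in this assay. Among the three numbers, compound 1 stands lowest, with compound 3 nearest and compound 2 furthest away, the gap to compound 2 lying beyond the scatter.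

Compound 4 `O=C1[C@@H](NS(=O)(=O)c2ccc(-c3ccon3)s2)CCN1Cc1cc2c[nH]ccc-2n1` has not yet been measured in this assay. It differs from compound 1 in one place: a group of 9 heavy atoms (7 carbon, 2 nitrogen; one five-membered aromatic ring with 1 hetero atom, one six-membered aromatic ring with 1 hetero atom) in place of a group of 8 heavy atoms (6 carbon, 2 nitrogen; one six-membered aromatic ring with 1 hetero atom), on a saturated chain carbon bound to an amide-type nitrogen in a ring. Among the compounds with values here, no step between two measured compounds shows the effect of exactly this change, so the expectation rests on the spread of the numbers already seen. Within the data shown here, a moderate rise in inhibition beyond the scatter is expected, because compound 2 gives 37% and shows that this series can reach numbers well above the one of compound 1. The step from compound 1 to compound 4 is estimated at a number 13 percentage points higher from compound 1 to compound 4 (beyond the scatter). Compound 4 is therefore expected to give about 35% in this assay, within a range from 15% to 55%.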

Compound 4, a percentage reported as inhibition, at one concentration (the size of the read-out at that concentration, not a potency): 17%
Compound 4: middle estimate off by 18 percentage points, on the high side, and the stated range covers the measured number.
By their numbers in this assay, from the lowest: compounds 4, 1 and 3 (each within the scatter of the next); then compound 2.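

In this assay, for the compounds shown here, the first readable step at this position, a saturated chain carbon bound to an amide-type nitrogen in a ring, is a number 5 percentage points lower from compound 1 to compound 4 (within the scatter), so exchanging the ((pyridin-4-yl)amino)methyl group for the two-ring group of compound 4 gives two compounds that cannot be told apart. The same two-ring group also stands in compound 2, which gives 37%, whereas compound 4 gives 17%, so in this small set the group alone does not bring the higher number; the two compounds differ in the part bound to the sulfonyl group. Nothing available explains why the exchange shows no clear effect in this assay.

On these data alone, it remains open whether a group of another kind at this position, such as a plain phenyl ring, a primary amine or a carboxylic acid, would give a step beyond the scatter. Also open, as far as these compounds go, are whether the exchange would give a similar step with the sulfonyl-bound part of compound 3, and how the compounds compare in potency, since each number comes from a single concentration.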